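From methylamino to methoxy on a shared core

This account rests on a few compounds, and the source may have more. Where it says the series, first, only, none or still open, it means among the compounds named here.

Measured compounds:
Compound 1 `CNC(=O)C1=C[C@@H]2[C@@H](C(C)C)CC[C@@]3(CO3)[C@H]2C(=O)OC1`: 5540 nM
Compound 2 `CNC(=O)C1=C[C@@H]2[C@@H](C(C)C)CC[C@@](O)(CO)[C@H]2C(=O)OC1`: > 32000 nM

Among the measured compounds shown here, in a functional assay on A549 cells (Homo sapiens) for inhibition, with a stated time of 72 h (on this read-out higher numbers stand for weaker inhibition and lower numbers for stronger inhibition), compound 1 gives 5540 nM, the only actual number available so far. For compound 2 the reading of > 32000 nM is a limit of the assay. The next compound, compound 3 `COC(=O)C1=C[C@@H]2[C@@H](C(C)C)CC[C@@]3(CO3)[C@H]2C(=O)OC1`, keeps the core of compound 1 and changes a single group: methoxy in place of methylamino on a carbonyl carbon. In words, methoxy stands in place of methylamino on a carbonyl carbon. For the measured compounds named here, no measured step in this assay covers this change, so the expectation rests on compound 1 alone, at 5540 nM. A modest shift towards stronger inhibition is expected, not far beyond the usual scatter, and the range is kept wide. The expected change is a 1.6-fold lower number from compound 1 to compound 3 (0.20 log units; within the scatter). Compound 3 is estimated at 3500 nM, with an expected range of 900 nM to 14000 nM.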

Compound 3, half-maximal inhibitory concentration: 450 nM
Compound 3: middle estimate off by 7.8-fold (0.89 log units), on the high side, outside the stated range (below it).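

In this assay, among the compounds shown here, the change to methoxy in place of methylamino on a carbonyl carbon gives a 12-fold lower number from compound 1 to compound 3 (1.09 log units; beyond the scatter), so this place on the shared core, about which the earlier compounds said nothing, responds strongly to the group it carries. The change takes away the hydrogen-bond donor of methylamino and brings in the hydrogen-bond acceptor of methoxy, but a single pair cannot separate this count from any other difference between the two groups. Nothing measured here gives a reason for the size of this step.

The compounds shown leave open how an ethoxy group, a carboxylic acid or a dimethylamino group would read on this carbonyl carbon. On these data alone, compound 2 gives > 32000 nM, a limit of the assay, so whether the step carries over to its structure also stays open.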